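The source may report more compounds than this note shows. Statements on the series, on what has been measured and on what is new or still open speak of the compounds shown alone.

Working notes on the lactone series. Compound 1 `Cc1ccc(S(=O)(=O)NCc2cn(C[C@H](O)[C@H]3OC(=O)C(OCc4ccccc4)=C3OCc3ccccc3)nn2)cc1` carries a (((4-methylphenyl)sulfonyl)amino)methyl group on the triazole ring of the shared core. Going by the values given here, in a functional assay on HCT-116 cells (Homo sapiens) for antiproliferative activity, read by MTT assay, with a stated time of 72 h (a lower number here means a stronger inhibitor, a higher number a weaker inhibitor), compound 1 gives 13100 nM, the lowest of the three numbers measured so far. Compound 2 `O=C1O[C@H]([C@@H](O)Cn2cc(CNS(=O)(=O)c3ccc(Cl)cc3F)nn2)C(OCc2ccccc2)=C1OCc1ccccc1` gives 21600 nM in this assay, and the step of a 1.6-fold higher number from compound 1 to compound 2 (0.22 log units; within the scatter) is within the scatter. Compound 3 `O=C1O[C@H]([C@@H](O)Cn2cc(-c3cc(C(F)(F)F)cc(C(F)(F)F)c3)nn2)C(OCc2ccccc2)=C1OCc1ccccc1` gives 57200 nM in this assay, a gap from compound 1 that lies beyond the scatter.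

Compound 4 `O=C1O[C@H]([C@@H](O)Cn2cc(C3CC3)nn2)C(OCc2ccccc2)=C1OCc1ccccc1` is the next member. Relative to compound 1 the change is cyclopropyl in place of (((4-methylphenyl)sulfonyl)amino)methyl on an aromatic carbon. Among the compounds with values here, no measured step bears directly on this change: the single-place step from compound 1 to compound 2 alters only the aryl on the sulfonyl sulfur and is within the scatter, so it says nothing about removing the whole sulfonamide arm. The two values of compound 1 and compound 3 show that a quite different substituent on the same ring position gave a markedly higher number, which is the only hint available. On that slender basis a loss is expected, a 3.1-fold higher number from compound 1 to compound 4 (0.48 log units; beyond the scatter), with wide uncertainty. Compound 4 is estimated at 40000 nM in this assay, in a range from 12000 nM to 130000 nM.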

Compound 4, half-maximal inhibitory concentration: 30400 nM
Compound 4: the middle estimate sits 1.3-fold (0.12 log units) above what was measured; measured number inside the range.
By their numbers in this assay, from the lowest: compounds 1, 2, 4 and 3 (each within the scatter of the next, the first and the last beyond it).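

Removing the whole (((4-methylphenyl)sulfonyl)amino)methyl group, with its 12 heavy atoms, six-membered aromatic ring, hydrogen-bond donor and hydrogen-bond acceptors, and putting cyclopropyl with 3 heavy atoms on the same aromatic carbon gives a 2.3-fold higher number from compound 1 to compound 4 (0.37 log units; beyond the scatter). The earlier compounds shown here changed only the aryl on the sulfonyl sulfur or exchanged the arm for another aryl group, whereas in this assay compound 4 still gives 30400 nM with no sulfonyl, no aryl ring and no donor in this substituent, so a measurable number at this position does not depend on the sulfonamide arm, and the cost of losing it is modest. No measurement on hand accounts for the size of this step.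

The sulfonyl, the amino hydrogen and the aryl ring all leave together in this change, so their separate shares in the step stay unresolved, and a plain benzyl group or a methanesulfonylaminomethyl group on the same carbon would separate them. Also open, on these data alone, is how the number responds on this carbon to a primary amine, a carboxylic acid or a longer alkyl chain in place of cyclopropyl.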